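The compounds below may be only part of what the source reports. "The series", "measured", "known", "first", "only" and "open" are said of these compounds alone.

Measured so far:
compound 1 `CCOc1cc(NC(=O)NCc2cc(C)c(-c3cn(C)nc3C(F)(F)F)nn2)cc(C#N)n1` in an ADME assay on microsomes from liver (Mus musculus) for metabolic stability, read by LC-MS, with a stated time of 4 h, tested at 1 uM; a higher number here means faster removal of the compound, a lower number slower removal: < 105 mL/min/kg
compound 2 `CCOc1nc(Cl)cc(NC(=O)NCc2cc(C)c(-c3cn(C)nc3C(F)(F)F)nn2)c1C` in this assay : < 534 mL/min/kg

The value of compound 1 is a limit of the assay and not a number. The value of compound 2 is also a limit of the assay. Compound 2 therefore stands nowhere definite on the numbers shown: its clearance is known only as a limit, and the other value shown is a limit too. The step that the two limits leave unreadable from compound 1 to compound 2 cannot be read, since the limit of < 105 mL/min/kg in this assay, at which 1 of the 2 values shown sits, and the limit of < 534 mL/min/kg in this assay, at which 1 of the 2 values shown sits, are the two limits at which the values sit.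

Compound 3 `CCOc1nc(C#N)cc(NC(=O)NCc2cc(C)c(-c3cn(C)nc3C(F)(F)F)nn2)c1C` has not been measured. It differs from compound 2 by cyano in place of chloro on an aromatic carbon. For the measured compounds named here, the only measured step, the one from compound 1 to compound 2, is unreadable, so no measured step gives a size or a direction for this change. The step expected from compound 2 to compound 3 is therefore a step that the limit leaves unreadable from compound 2 to compound 3, with no direction beyond the scatter claimed. Compound 3 is estimated at 60 mL/min/kg, with a range from 15 mL/min/kg to 250 mL/min/kg, in this assay.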

Compound 3, clearance: < 164 mL/min/kg
Compound 3 gave a limit, no number; the forecaster's own chance of this, stated with the estimate: 60%; the middle value does not contradict the limit.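

In this assay compound 3 gives < 164 mL/min/kg, a limit of the assay and not a number. The steps joining compound 3 to compound 1 and to compound 2 cannot be read. As far as these compounds go, the clearance of all three compounds stays open, as does whether cyano in place of chloro, or methyl in place of hydrogen, changes it.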